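Adding a Second Bromo to Compound 3

This account rests on a few compounds, and the source may have more. Where it says the series, first, only, none or still open, it means among the compounds named here.

Measured so far in a functional assay on HEK293 cells for agonist activity at Neuronal acetylcholine receptor; alpha4/beta2 (Homo sapiens), read by FLIPR; a lower number here means that less compound is needed, a higher number that more compound is needed for the effect:
compound 1 `c1cncc(N2CC[C@@H]3CN[C@@H]3C2)c1`: 330 nM
compound 2 `Brc1cncc(N2CC[C@H]3CN[C@H]3C2)c1`: 150 nM
compound 3 `Brc1cncc(N2CC[C@@H]3CN[C@@H]3C2)c1`: 1000 nM

Compound 3 stands highest of the three numbers. Its mirror image, compound 2, sits lowest, and the gap between them, a 6.7-fold higher number from compound 2 to compound 3 (0.82 log units; beyond the scatter), rests only on (the fact that compounds 2 and 3 differ only in the configuration as drawn). The nearer neighbour is compound 1, with a 3.0-fold higher number from compound 1 to compound 3 (0.48 log units; beyond the scatter).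

Compound 4 `Brc1cc(N2CC[C@@H]3CN[C@@H]3C2)cnc1Br` carries one further change: bromo in place of hydrogen on an aromatic carbon. Within the data shown here, only one measured step bears on this, the bromo added in a 3.0-fold higher number from compound 1 to compound 3 (0.48 log units; beyond the scatter), which raised the number modestly. A second bromo is therefore expected to raise the number again, by about a 2.0-fold higher number from compound 3 to compound 4 (0.30 log units; within the scatter). For compound 4 the estimate is 2000 nM, within the range 600 nM to 7000 nM.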

Compound 4, half-maximal effective concentration: 76 nM
Compound 4: middle estimate off by 26-fold (1.42 log units), on the high side; the measured number lies below the stated range.
By their numbers in this assay, from the lowest: compounds 4 and 2 (each within the scatter of the next); then compound 1; then compound 3.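

Bromo in place of hydrogen lowers the number here (a 13-fold lower number from compound 3 to compound 4 (1.12 log units; beyond the scatter)), while the other bromo step went the opposite way (a 3.0-fold higher number from compound 1 to compound 3 (0.48 log units; beyond the scatter)). The same change on this ring therefore has no single direction: its outcome depends on where it lands, here next to the ring nitrogen and ortho to a bromo group. Nothing available explains this reversal.

On these data alone, it remains open whether this place alone or its pairing with the other bromo accounts for the drop. Also open, as far as these compounds go, are what a chloro or a methyl would do here and whether compound 2 would respond alike.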